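The compounds below may be only part of what the source reports. "The series", "measured", "known", "first", "only" and "open" are said of these compounds alone.

Measured compounds in an assay on isolated protein for inhibition of phosphodiesterase 4A (Sus scrofa); on this read-out higher numbers stand for weaker inhibition and lower numbers for stronger inhibition:
compound 1, `COc1ccc(C(=O)Nc2ccccc2O)cc1OC1CCCC1`, gives 1300 nM
compound 2, `COc1ccc(C(=O)Nc2cnccn2)cc1OC1CCCC1`, gives 250 nM
compound 3, `COc1ccc(C(=O)Nc2nccs2)cc1OC1CCCC1`, gives 6500 nM

Compound 3 stands highest of the three numbers, the weakest inhibitor shown: the step of a 5.0-fold higher number from compound 1 to compound 3 (0.70 log units; beyond the scatter) is modest, and the step of a 26-fold higher number from compound 2 to compound 3 (1.41 log units; beyond the scatter) is large. Compound 4, `COc1ccc(C(=O)NC2(C)C=C(C)ON2)cc1OC1CCCC1`, differs from compound 3 only on the amide-type nitrogen: a group of 7 heavy atoms (5 carbon, 1 nitrogen, 1 oxygen; one five-membered non-aromatic ring with 2 hetero atoms) in place of a group of 5 heavy atoms (3 carbon, 1 nitrogen, 1 sulfur; one five-membered aromatic ring with 2 hetero atoms), on an amide-type nitrogen. All three measured steps swap the group on that nitrogen, so they bear on this place, and their sizes ran from modest (a 5.2-fold lower number from compound 1 to compound 2 (0.72 log units; beyond the scatter)) to large. None of them, though, exchanges an aromatic ring for a non-aromatic one, so their direction cannot be carried over. Since compound 3 already has the highest number, a further rise or a modest fall are both open. The expectation for compound 4 is therefore a step near the scatter, a 1.1-fold lower number from compound 3 to compound 4 (0.03 log units; within the scatter), with wide uncertainty. Compound 4 is estimated at 6000 nM, within a range of 1200 nM to 30000 nM.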

Compound 4, half-maximal inhibitory concentration: 450 nM
Beside the measured number, compound 4's estimate is 13-fold (1.12 log units) above it; the whole stated range lies above it.
By their numbers in this assay, from the lowest: compounds 2 and 4 (each within the scatter of the next); then compound 1; then compound 3.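

In this assay, the non-aromatic five-membered ring on the amide-type nitrogen gives a large change against the aromatic thiazole (a 14-fold lower number from compound 3 to compound 4 (1.16 log units; beyond the scatter)), so among these compounds an aromatic ring is not required at this place. Against the pyrazin-2-yl group the same ring stays within the scatter (a 1.8-fold higher number from compound 2 to compound 4 (0.26 log units; within the scatter)), and against the 2-hydroxyphenyl group the step is modest (a 2.9-fold lower number from compound 1 to compound 4 (0.46 log units; beyond the scatter)). Nothing given here explains why the two five-membered rings lie so far apart.

With only one non-aromatic ring shown, it remains open whether its double bond, its methyl groups or its ring nitrogen hydrogen matter. Also open, from the compounds shown here alone, is how a cyclopentyl, a piperidin-4-yl or a pyridin-2-yl group would read on this nitrogen.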